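The source may report more compounds than this note shows. Statements on the series, on what has been measured and on what is new or still open speak of the compounds shown alone.

Of the compounds shown here, three built on one shared core have been tested in a functional assay on KB cells (Homo sapiens) for antiproliferative activity, read by sulforhodamine B assay, with a stated time of 3 days; a lower number here means that less compound is needed, a higher number that more compound is needed for the effect. Compound 1 `CCC1=C(O)c2c(oc(-c3ccc(C(C)C)cc3)cc2=O)C(CC)(CC)C1=O` gives 8.13 uM, the lowest of the three numbers. Compound 2 `CCC1=C(O)c2c(oc(-c3ccccc3C)cc2=O)C(CC)(CC)C1=O` gives 40.9 uM, and compound 3 `CCC1=C(O)c2c(oc(-c3ccc(C)c(C)c3)cc2=O)C(CC)(CC)C1=O` gives 35.5 uM. Changing the aryl group of compound 1 produced a 5.0-fold higher number from compound 1 to compound 2 (0.70 log units; beyond the scatter) and a 4.4-fold higher number from compound 1 to compound 3 (0.64 log units; beyond the scatter), whereas a 1.2-fold lower number from compound 2 to compound 3 (0.06 log units; within the scatter) was recorded. Compound 4 `CCC1=C(O)c2c(oc(-c3ccc(OC)c(C)c3)cc2=O)C(CC)(CC)C1=O` remains unmeasured; its change from compound 1 is 4-methoxy-3-methylphenyl in place of 4-isopropylphenyl on an aromatic carbon. Both measured departures from the 4-isopropylphenyl group raised the number by a modest amount, so a modest rise of the same kind is expected for this new aryl group as well. Compound 4 is therefore estimated at 25 uM, with a range from 10 uM to 60 uM, which corresponds to an expected step of a 3.1-fold higher number from compound 1 to compound 4 (0.49 log units; beyond the scatter).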

Compound 4, concentration for half-maximal effect: 28.5 uM
Beside the measured number, compound 4's estimate is 1.1-fold (0.06 log units) below it; low and high end bracket the measured number.
By their numbers in this assay, from the lowest: compound 1; then compounds 4, 3 and 2 (each within the scatter of the next).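

The 4-methoxy-3-methylphenyl group brings an oxygen and a hydrogen-bond acceptor that 4-isopropylphenyl lacks, yet it does not reach compound 1 (a 3.5-fold higher number from compound 1 to compound 4 (0.54 log units; beyond the scatter)). Methoxy in place of methyl changes little (a 1.2-fold lower number from compound 3 to compound 4 (0.10 log units; within the scatter)), and the comparison with the 2-methylphenyl group is just as flat (a 1.4-fold lower number from compound 2 to compound 4 (0.16 log units; within the scatter)), so this position has now taken an oxygen without a clear shift among these three compounds, and no measurement explains these numbers. Open, on these data alone, is whether a 4-ethylphenyl or 4-tert-butylphenyl group would keep the lower number of compound 1, and what an amine or a carboxylic acid on this aryl ring would do.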